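Swapping a small amine for a ring on the chain

A few compounds are considered here, and "the series" means these few. Any claim that something is new, unique, unknown or untested is made for them only; others in the source may bear on it.

Measured so far, in a functional assay on MDA-MB-231 cells (Homo sapiens) for cytotoxicity, read by sulforhodamine B assay, with a stated time of 48 h; a lower number here means a stronger inhibitor of growth, a higher number a weaker inhibitor of growth:
- compound 1 `Cc1ccc2nc(/N=C3\C(=O)N(CN4CCCCC4)c4ccccc43)sc2c1`: 34500 nM
- compound 2 `Cc1ccc2nc(/N=C3\C(=O)N(CN(C)C)c4cccc(Br)c43)sc2c1`: 49000 nM

Compound 2 gives the highest of the two numbers, but its nearest neighbour, compound 1, sits within the usual scatter of it, so the two cannot be put in order. For the measured compounds named here, compound 1 and compound 2 differ in more than one place, so their pair gives no single-change step to lean on.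

Compound 3 `Cc1ccc2nc(/N=C3\C(=O)N(CN4CCCCC4)c4cccc(Br)c43)sc2c1` has not yet been measured. It differs from compound 2 in one place: piperidin-1-yl in place of dimethylamino on a saturated chain carbon bound to an amide-type nitrogen in a ring. Going by the values given here, nothing among the measured pairs shows how this change alone moves the number, so the expectation for this assay is a step of no more than the scatter, in no firm direction.

Compound 3 is therefore estimated at 40000 nM, within a range of 15000 nM to 110000 nM, which means an expected step of a 1.2-fold lower number from compound 2 to compound 3 (0.09 log units; within the scatter).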

Compound 3, concentration for 50% growth inhibition: 38300 nM
Compound 3: middle estimate off by 1.0-fold (0.02 log units), on the high side; low and high end bracket the measured number.
By their numbers in this assay, from the lowest: compounds 1, 3 and 2 (each within the scatter of the next).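

In this assay, piperidin-1-yl in place of dimethylamino on the chain gives a 1.3-fold lower number from compound 2 to compound 3 (0.11 log units; within the scatter) and so, with the bromo group present, this swap of a small amine for a ring has no effect that can be told from the scatter. Bromo in place of hydrogen on an aromatic carbon gives a 1.1-fold higher number from compound 1 to compound 3 (0.05 log units; within the scatter) and so, with the piperidin-1-yl group present, this change cannot be told from the scatter either. No measurement shown here bears on why these numbers stay so close.

As far as these compounds go, whether a morpholin-4-yl group or a longer chain would shift the number at the amine end remains open, as does the effect of chloro or methoxy in place of bromo. With all three compounds within the scatter of their neighbours, the compounds shown do not yet reveal which part of the structure controls growth inhibition.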